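This account rests on a few compounds, and the source may have more. Where it says the series, first, only, none or still open, it means among the compounds named here.

Working notes on the series. Compound 1 `CCN(CC)c1ccc2cc(C(=O)c3ccc(N4CCN(C(=O)CN5CCN(S(=O)(=O)c6ccc(C(F)(F)F)cc6)CC5)CC4)cc3)oc2c1` gives 32200 nM in a functional assay on HCT-116 cells (Homo sapiens) for cytotoxicity, read by MTT assay, with a stated time of 48 h; on this read-out higher numbers stand for weaker inhibition and lower numbers for stronger inhibition. Compound 2 `CCN(CC)c1ccc2cc(C(=O)c3ccc(N4CCN(C(=O)CN5CCN(S(=O)(=O)c6ccc(C#N)cc6)CC5)CC4)cc3)oc2c1` gives 36400 nM in this assay; the step of a 1.1-fold higher number from compound 1 to compound 2 (0.05 log units; within the scatter) is a swap of one aryl substituent for another and leaves the number essentially unchanged. Within the data shown here, on the two numbers so far, compound 2 stands highest, but only within the scatter of compound 1, so no order between the two can be read from them.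

Compound 3 `CCN(CC)c1ccc2cc(C(=O)c3ccc(N4CCN(C(=O)CN5CCN(Cc6ccc(C#N)cc6)CC5)CC4)cc3)oc2c1` is the next member to be placed. Its change from compound 2 is 4-cyanobenzyl in place of (4-cyanophenyl)sulfonyl on an amine nitrogen in a ring. Among the measured compounds shown here, the one measured step, from compound 1 to compound 2, concerns a different position and a different kind of exchange; it bears on the new step only in showing that the series sits at weak inhibition and has so far not moved beyond the scatter. For the measured compounds named here, no measured step addresses a sulfonyl-to-benzyl exchange on the ring nitrogen, so the direction of this assay for compound 3 is open. The step of a 1.2-fold lower number from compound 2 to compound 3 (0.08 log units; within the scatter) is therefore expected to be small, with a wide band of uncertainty. Compound 3 is estimated at 30000 nM, within 10000 nM to 90000 nM.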

Compound 3, half-maximal inhibitory concentration: > 40000 nM
Compound 3: no number, only a limit (the forecaster's own chance of this, stated with the estimate: 20%); at least 1.3-fold (0.12 log units) between middle value and limit.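

Compound 3 gives only a limit in this assay, > 40000 nM. Going by these compounds, compounds 1 and 2 both carry a sulfonyl group on this ring nitrogen, so they said nothing about exchanging that link; with 4-cyanobenzyl in place of (4-cyanophenyl)sulfonyl, the step is an at least 1.0-fold higher number from compound 2 to compound 3 (0.04 log units; that floor lies within the scatter), and the true size of this step stays unknown. This change therefore gives no sign of stronger inhibition, and the series stays at the weak end of the read-out, with one compound now at the limit of the assay: the limit of > 40000 nM in this assay, at which 1 of the 3 values shown sits.

The compounds shown leave open whether any group on this ring nitrogen can move the number beyond the scatter, such as a simple acyl group, a short alkyl chain or an unsubstituted benzyl. Among these compounds, they also leave open whether the outcome belongs to the link or to the aryl ring it carries, as the 4-cyanophenyl ring is the only aryl group seen on both a sulfonyl and a methylene link, and a benzyl bearing trifluoromethyl would be a second such pair.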